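Replacing methylsulfonyl with cyano: an expected clearance

The compounds below may be only part of what the source reports. "The series", "measured", "known", "first", "only" and "open" are said of these compounds alone.

- Compound 1 `O=C(Nc1cccnc1-c1ccsc1)N1CCN2C(=O)N([C@H]3C[C@@H]3c3ccccc3)C(=O)[C@@H]2C1`: 40000 mL.min-1.g-1
- Compound 2 `CS(=O)(=O)c1cc(Cl)c(NC(=O)N2CCN3C(=O)N([C@H]4C[C@@H]4c4ccccc4)C(=O)[C@@H]3C2)c(Cl)c1`: 58000 mL.min-1.g-1

Both numbers come from an in vitro ADME assay on microsomes from liver (Homo sapiens) for metabolic stability; on this read-out lower numbers stand for slow clearance and higher numbers for fast clearance. Compound 2 and compound 1 lie within the usual scatter of each other, so this read-out cannot tell them apart, and both sit on the fast-clearance side of what has been seen so far only in the sense that nothing slower has been measured.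

Compound 3 `N#Cc1cc(Cl)c(NC(=O)N2CCN3C(=O)N([C@H]4C[C@@H]4c4ccccc4)C(=O)[C@@H]3C2)c(Cl)c1` differs from compound 2 in one place: cyano in place of methylsulfonyl on an aromatic carbon, meta to two chloro groups and para to a large group (cyano in place of methylsulfonyl on an aromatic carbon). Among the measured compounds shown here, no measured pair shows what this swap does. With compound 2 at 58000 mL.min-1.g-1 as the starting point, no change beyond the scatter is expected in this assay.

The expected step is a 1.2-fold lower number from compound 2 to compound 3 (0.06 log units; within the scatter). For compound 3 the estimated value is 50000 mL.min-1.g-1, with a range from 25000 mL.min-1.g-1 to 100000 mL.min-1.g-1.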

Compound 3, intrinsic clearance in microsomes: 66000 mL.min-1.g-1
Compound 3: the middle estimate sits 1.3-fold (0.12 log units) below what was measured, and the stated range covers the measured number.
By their numbers in this assay, from the lowest: compounds 1, 2 and 3 (each within the scatter of the next).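

In this assay, among the compounds shown here, cyano in place of methylsulfonyl on this aromatic carbon gives a 1.1-fold higher number from compound 2 to compound 3 (0.06 log units; within the scatter), the first measured pair for this swap, so the read-out cannot tell these two groups apart at this position. Replacing the whole group on the amide-type nitrogen, with 2,6-dichloro-4-cyanophenyl in place of 2-(thiophen-3-yl)pyridin-3-yl, gives a 1.7-fold higher number from compound 1 to compound 3 (0.22 log units; within the scatter), so that larger swap also stays inside what repeated measurements would scatter by. No supporting data are available to explain these results.

From the compounds shown here alone, whether an amine or a carboxylic acid on the same aromatic carbon would give a number beyond the scatter remains open. Also open, going by these compounds, is whether any change to the shared core, rather than to this aromatic group, would lead to slower clearance.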